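Lengthening the Amide Chain on a Melatonin Receptor Ligand

This account rests on a few compounds, and the source may have more. Where it says the series, first, only, none or still open, it means among the compounds named here.

Measured so far in an assay on isolated protein for agonist activity at melatonin receptor type 1C (Xenopus laevis), read by spectrophotometry; on this read-out higher numbers stand for an effect only at larger amounts of compound and lower numbers for an effect already at smaller amounts:
compound 1 `CCCC(=O)NCc1ccc(OC)c(F)c1` gives 661 nM
compound 2 `CCC(=O)NCCCc1ccc(F)c(OC)c1` gives 1.1 nM

Compound 2 holds the lowest of the two numbers, and its nearest neighbour, compound 1, gives a far higher one, a gap beyond the usual scatter. Compound 3 `CCCC(=O)NCCCc1ccc(F)c(OC)c1` differs from compound 2 by methyl in place of hydrogen on a saturated chain carbon, two bonds along the chain from a carbonyl carbon. Among the compounds with values here, no measured pair differs in just this way, so the step has no precedent here. A change of this kind is expected to stay within the scatter, in no settled direction, giving an estimated step of a 1.1-fold lower number from compound 2 to compound 3 (0.04 log units; within the scatter). Compound 3 is therefore estimated at 1 nM, with a range from 0.3 nM to 4 nM.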

Compound 3, half-maximal effective concentration: 0.891 nM
For compound 3 the middle estimate is 1.1-fold (0.05 log units) above the measured one, within the range that was stated.
By their numbers in this assay, from the lowest: compounds 3 and 2 (each within the scatter of the next); then compound 1.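

In this assay the step is a 1.2-fold lower number from compound 2 to compound 3 (0.09 log units; within the scatter) and so compound 2 and compound 3 cannot be told apart. Methyl in place of hydrogen on this saturated chain carbon, two bonds along the chain from a carbonyl carbon, is therefore tolerated here, which the earlier compounds could not show. Nothing measured here offers a reason for this. Still open, as far as these compounds go, is whether a longer chain, a branched isopropyl group or a cyclopropyl ring at this end of the amide would also be tolerated.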